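Swapping Hydroxy for Amino at the Weak End of the Series

The source may hold more compounds than are shown below. What is called first, only, known or untested is meant among the compounds shown, and "the series" means these compounds.

Of the compounds shown here, three have so far been measured in a functional assay for inhibition of sodium/hydrogen exchanger (Oryctolagus cuniculus); on this read-out higher numbers stand for weaker inhibition and lower numbers for stronger inhibition. Compound 1 `Cc1cc(F)c(S(C)(=O)=O)cc1C(=O)N=C(N)N` gives 44 nM, and compound 2 `Cc1cc(-c2ccc(Cl)cc2Cl)c(S(C)(=O)=O)cc1C(=O)N=C(N)N` gives 42 nM; the step of a 1.0-fold lower number from compound 1 to compound 2 (0.02 log units; within the scatter) lies within the scatter. Compound 3 `Cc1cc(O)c(S(C)(=O)=O)cc1C(=O)N=C(N)N` gives 220 nM, the highest of the three numbers, and the steps of a 5.0-fold higher number from compound 1 to compound 3 (0.70 log units; beyond the scatter) and a 5.2-fold higher number from compound 2 to compound 3 (0.72 log units; beyond the scatter) are both beyond the scatter, so compound 3 stands clearly apart from the other two as the weakest inhibitor on this read-out.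

Compound 4 `Cc1cc(N)c(S(C)(=O)=O)cc1C(=O)N=C(N)N` has not yet been measured. It differs from compound 3 in one place: amino in place of hydroxy on an aromatic carbon. The measured steps that bear on this position are the two leading into compound 3, a 5.0-fold higher number from compound 1 to compound 3 (0.70 log units; beyond the scatter) and a 5.2-fold higher number from compound 2 to compound 3 (0.72 log units; beyond the scatter), both modest and both pointing toward weaker inhibition when hydroxy enters at that carbon. Within the data shown here, no measured step shows amino at this place, so the consequence of exchanging hydroxy for amino cannot be read directly from the numbers in hand.

The expected step of a 1.5-fold lower number from compound 3 to compound 4 (0.17 log units; within the scatter) is therefore small, with its direction uncertain and leaning only slightly toward stronger inhibition. Compound 4 is estimated at 150 nM, with a range from 50 nM to 450 nM.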

Compound 4, half-maximal inhibitory concentration: 16 nM
Beside the measured number, compound 4's estimate is 9.4-fold (0.97 log units) above it, and the stated range ends above it.
By their numbers in this assay, from the lowest: compound 4; then compounds 2 and 1 (each within the scatter of the next); then compound 3.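

In this assay the exchange of hydroxy for amino gives a 14-fold lower number from compound 3 to compound 4 (1.14 log units; beyond the scatter) even though the two groups match in their heavy-atom, hydrogen-bond donor and acceptor counts and neither carries a net charge, so this position responds strongly to a change that these counts do not register. Amino also goes beyond the two groups that had stood within the scatter of each other at this carbon, with a 2.6-fold lower number from compound 2 to compound 4 (0.42 log units; beyond the scatter) and a 2.8-fold lower number from compound 1 to compound 4 (0.44 log units; beyond the scatter) as well, which makes compound 4 the strongest inhibitor of the four and shows that a change at this carbon can strengthen inhibition beyond the level of fluoro and 2,4-dichlorophenyl as well as weaken it. The information at hand offers no measured account of why amino and hydroxy differ so much here.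

On these data alone, it remains open whether methylamino, dimethylamino or methoxy on this aromatic carbon would keep, lose or extend the strength seen with amino. As far as these compounds go, it is also open whether the gain from amino would carry over to a core with ethylsulfonyl in place of the methylsulfonyl group.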